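The compounds below may be only part of what the source reports. "The series", "measured", "known", "first", "only" and "open" are said of these compounds alone.

Measured so far in a functional assay on HepG2 cells (Homo sapiens) for antiproliferative activity, read by sulforhodamine B assay, with a stated time of 48 h; on this read-out higher numbers stand for weaker inhibition and lower numbers for stronger inhibition:

- compound 1, `COc1cc(C2=CC(c3ccc(F)cc3)NC(=S)N2)cc(OC)c1OC`: 61.9 nM
- compound 2, `COc1ccc(C2=CC(c3ccc(Br)cc3)NC(=S)N2)cc1`: 30 nM
- compound 3, `COc1cccc(C2=CC(c3ccc(Cl)cc3)NC(=S)N2)c1`: 54 nM

Compound 1 gives the highest of the three numbers in this assay. Its nearest neighbour is compound 3, whose value lies within the usual scatter of compound 1, so the two cannot be told apart on these numbers. The furthest is compound 2, which gives a number that stands beyond the scatter, lower than that of compound 1. Compounds 2 and 3 differ from compound 1 in more than one place each, so none of these pairs offers a single-change step to lean on.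

Compound 4, `COc1cc(C2=CC(c3ccc(Cl)cc3)NC(=S)N2)cc(OC)c1OC`, is not yet measured. It differs from compound 1 in one place: chloro in place of fluoro on an aromatic carbon. Nothing in the series isolates this change alone. The three measured values all sit in a narrow window, and the changes among them that involve the halogen are mixed with changes elsewhere on the shared core. The step from compound 1 to compound 4 in this assay is therefore expected to be small, at most at the edge of the scatter, and its direction cannot be read from these data with confidence; a slightly lower number is taken as the more likely case, as a 1.2-fold lower number from compound 1 to compound 4 (0.09 log units; within the scatter) expresses. Compound 4 is estimated at 50 nM, with a range from 25 nM to 120 nM.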

Compound 4, half-maximal inhibitory concentration: 11 nM
For compound 4 the middle estimate is 4.5-fold (0.66 log units) above the measured one; measured number outside the range, below it.
By their numbers in this assay, from the lowest: compound 4; then compounds 2, 3 and 1 (each within the scatter of the next, the first and the last beyond it).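

On the core of compound 1, chloro in place of fluoro on an aromatic carbon, para to a large group, gives a 5.6-fold lower number from compound 1 to compound 4 (0.75 log units; beyond the scatter) in this assay, so this position responds clearly to the identity of the halogen. Among the compounds shown here, this is the first step that isolates a single change, and its size could not be seen in the earlier compounds, where any halogen difference came mixed with changes elsewhere on the shared core; here one heavy atom replaces one heavy atom, with no ring, hydrogen-bond donor or hydrogen-bond acceptor entering or leaving. No measurement at hand accounts for the step, and its origin stays unassigned.

Bromo appears only in compound 2, which differs from compound 1 in more than one place, so it remains open how bromo would compare with chloro and fluoro on the core of compound 1, and whether the fluoro-to-chloro step would carry over to other cores in the series. Also open, from the compounds shown here alone, is how a trifluoromethyl, a nitrile or a methyl would fare at this same place.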